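The compounds below may be only part of what the source reports. "The series", "measured", "known", "first", "only" and "open" are said of these compounds alone.

In a functional assay on MCF7 cells (Homo sapiens) for antiproliferative activity, read by MTT assay, with a stated time of 72 h (a higher number here means a weaker inhibitor, a lower number a stronger inhibitor), compound 1 `CNc1nc(-c2cc(OC)c(OC)c(OC)c2)c(-c2ccc3ccccc3c2)s1` gives 21.1 nM, and compound 2 `CNc1nc(-c2cc(OC)c(OC)c(OC)c2)c(-c2ccc(C)cc2)s1` gives 10.1 nM. Compound 1 therefore holds the higher of the two numerical values, with a gap beyond the usual scatter. Compound 3 `CCOc1ccc(-c2sc(N(C)C)nc2-c2cc(OC)c(OC)c(OC)c2)cc1` reaches only a limit of the assay, > 10000 nM, so it provides no number. Compound 3 also differs from compound 1 in more than one place, so it offers only a loose warning that this series can lose its activity in this assay.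

Compound 4 `COc1cc(-c2nc(C)sc2-c2ccc3ccccc3c2)cc(OC)c1OC` has not yet been measured. It keeps the core of compound 1 but has methyl in place of methylamino on an aromatic carbon, and the hydrogen-bond donor leaves with that group. For the measured compounds named here, no measured pair isolates this change, so the size of the step is uncertain. A weakening beyond the scatter in this assay is expected, meaning a higher number. The estimated change is a 12-fold higher number from compound 1 to compound 4 (1.07 log units; beyond the scatter). For compound 4, the estimated value is 250 nM, with an expected range from 25 nM to 4000 nM.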

Compound 4, half-maximal inhibitory concentration: 33.4 nM
Compound 4: middle estimate off by 7.5-fold (0.87 log units), on the high side; the measured number falls inside the stated range.
By their numbers in this assay, from the lowest: compound 2; then compounds 1 and 4 (each within the scatter of the next). At a limit, above all of these: compound 3.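

In this assay, replacing methylamino with methyl on this aromatic carbon gives a 1.6-fold higher number from compound 1 to compound 4 (0.20 log units; within the scatter) and so lies within the scatter, which means the two groups cannot be told apart here. The hydrogen-bond donor leaves with methylamino, so with the rest of compound 1 in place, activity at this level does not require a donor on this carbon. Nothing measured here explains why the two groups read alike.

The compounds shown leave open whether other groups on this carbon, such as a primary amine, an ethyl chain or a carboxylic acid, would also hold this level. They also leave open whether methyl in place of methylamino would read the same way on the core of compound 2.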